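The compounds below may be only part of what the source reports. "The series", "measured", "known", "first", "only" and "open" are said of these compounds alone.

Compound 1 `CCOC(=O)c1nn(-c2ccc(Cl)cc2)c(-c2ccc(Br)cc2)c1CNC(C)(C)C` and compound 2 `CC(C)(C)NCc1c(C(=O)O)nn(-c2ccc(Cl)cc2)c1-c1ccc(Br)cc1` have both been tested in an ADME assay on HaCaT cells (Homo sapiens) for inhibition, read by sulforhodamine B assay, with a stated time of 48 h; on this read-out lower numbers stand for stronger inhibition of growth and higher numbers for weaker inhibition of growth. Compound 1 gives > 511000 nM; > 476000 nM (2 entries), and these entries are limits of the assay, not numbers. Compound 2 gives > 542000 nM, which is also a limit. A further entry for compound 2 likewise carries no single number, so it has no exact position on this scale. Compound 3 `CC(C)(C)NCc1c(C(=O)O)nn(-c2ccc(Cl)cc2)c1-c1ccc([N+](=O)[O-])cc1` has nitro in place of bromo on an aromatic carbon, para to a large group, which turns 4-bromophenyl into 4-nitrophenyl: nitro in place of bromo on an aromatic carbon. For the measured compounds named here, no measured step between compounds is available as a guide. Given only the limit of > 542000 nM for compound 2, no change beyond the scatter is expected in this assay. The expected size of the change is a step that the limit leaves unreadable from compound 2 to compound 3. For compound 3 the estimated value is 550000 nM, with an expected range of 200000 nM to 1000000 nM.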

Compound 3, concentration for 50% growth inhibition: > 583000 nM
Compound 3: a limit, no number; the forecaster's own chance of this, stated with the estimate: 80%; middle value at least 1.0-fold (0.02 log units) away from the limit.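

Compound 2 and compound 3 each carry only a limit in this assay, and the step between them cannot be read. The compounds shown leave open whether nitro in place of bromo changes growth inhibition at all, and where any of them sits on this scale.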